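Diethylamide to Cyclopropylamide on a Shared Core

The source may report more compounds than this note shows. Statements on the series, on what has been measured and on what is new or still open speak of the compounds shown alone.

Measured so far in an assay on isolated protein for inhibition of receptor-type tyrosine-protein phosphatase C (Homo sapiens), read by spectrophotometry; on this read-out higher numbers stand for weaker inhibition and lower numbers for stronger inhibition:
- compound 1 `CCN(CC)C(=O)COc1ccc2cc(C(O)(C(F)(F)F)C(F)(F)F)c(O)cc2c1` gives > 20000 nM, a limit of the assay.
- compound 2 `O=C(COc1ccc2cc(C(O)(C(F)(F)F)C(F)(F)F)c(O)cc2c1)Nc1ccccc1` gives > 20000 nM, also a limit.
- compound 3 `CC(C)c1ccc(NC(=O)COc2ccc3cc(C(O)(C(F)(F)F)C(F)(F)F)c(O)cc3c2)cc1` gives 7800 nM.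

Compound 1 thus stands at the limit, where two of the three values sit (the limit of > 20000 nM in this assay, at which 2 of the 3 values shown sit). Compound 4 `O=C(COc1ccc2cc(C(O)(C(F)(F)F)C(F)(F)F)c(O)cc2c1)NC1CC1` differs from compound 1 by cyclopropylamino in place of diethylamino on a carbonyl carbon. The relevant steps are a step that the two limits leave unreadable from compound 1 to compound 2 and an at least 2.5-fold lower number from compound 1 to compound 3 (0.40 log units; beyond the scatter); only the 4-isopropylphenyl amide moves below the limit, while the plain anilide does not. Cyclopropylamino is smaller than either, so compound 4 is expected to stay near the limit, with a step that the limit leaves unreadable from compound 1 to compound 4. Compound 4 is estimated at 25000 nM, between 8000 nM and 80000 nM.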

Compound 4, half-maximal inhibitory concentration: > 20000 nM
Compound 4 ended at the assay's limit (the forecaster's own chance of this, stated with the estimate: 70%); the middle value does not contradict the limit.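

In this assay, a cyclopropyl group on the amide nitrogen brings no gain that can be read: the steps to compound 4 from compound 1 and from compound 2 cannot be read, as both ends of each are limits. Among the compounds shown here, the one readable step is an at least 2.5-fold higher number from compound 3 to compound 4 (0.40 log units; beyond the scatter). Cyclopropyl thus joins diethylamino and phenyl at the limit, leaving 4-isopropylphenyl as the only amide group shown that comes off it: the limit of > 20000 nM in this assay, at which 3 of the 4 values shown sit.

As far as these compounds go, how far compound 1, compound 2 and compound 4 lie from one another stays open. So does whether a tert-butyl group or a longer alkyl chain on the phenyl ring would match or pass isopropyl.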